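This account rests on a few compounds, and the source may have more. Where it says the series, first, only, none or still open, it means among the compounds named here.

The three measured compounds are:
compound 1 `Cn1cc(C2CC(c3ccc(F)cc3)=NN2C(=O)c2cccnc2)c2cc(Br)ccc21`, 480 nM in a functional assay on HepG2 cells (Homo sapiens) for inhibition, read by MTT assay, with a stated time of 48 h; a lower number here means a stronger inhibitor of growth, a higher number a weaker inhibitor of growth;
compound 2 `Cn1cc(C2CC(c3ccc(Cl)cc3)=NN2C(=O)c2cccnc2)c2cc(Br)ccc21`, 5800 nM in this assay;
compound 3 `COc1ccc2c(c1)c(C1CC(c3ccc(F)cc3)=NN1C(=O)c1ccc(OC)nc1)cn2C`, 220 nM in this assay.

Compound 1 and compound 2 share one core and differ in a single place, (chloro in place of fluoro on an aromatic carbon). That change gave a 12-fold higher number from compound 1 to compound 2 (1.08 log units; beyond the scatter). Compound 3 sits on a different core; how the core of compound 3 differs from the core of compound 1 is not broken down here. Of the three, compound 3 has the lowest number, with compound 1 nearest and compound 2 furthest.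

Compound 4 `COc1ccc2c(c1)c(C1CC(c3ccc(Cl)cc3)=NN1C(=O)c1ccc(OC)nc1)cn2C` has not yet been measured. It differs from compound 3 in one place, (chloro in place of fluoro on an aromatic carbon), and the surroundings of that place read the same, word for word, as for the change from compound 1 to compound 2, so this is the same change, seen for the second time among these compounds. Among the measured compounds shown here, because the one measured instance gave a 12-fold higher number from compound 1 to compound 2 (1.08 log units; beyond the scatter), compound 4 is expected to be a weaker inhibitor of growth than compound 3. For compound 4 the expected step is a 9.1-fold higher number from compound 3 to compound 4 (0.96 log units; beyond the scatter). For the measured compounds named here, only one instance of the change has been measured, and it sits on another core, so this step is set a little smaller than the earlier one. In this assay compound 4 is estimated at 2000 nM, expected to fall between 600 nM and 7000 nM.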

Compound 4, concentration for 50% growth inhibition: 2080 nM
For compound 4 the middle estimate is 1.0-fold (0.02 log units) below the measured one, within the range that was stated.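

In this assay, chloro in place of fluoro on the aromatic carbon gave a 9.5-fold higher number from compound 3 to compound 4 (0.98 log units; beyond the scatter), so on this second core the 4-chlorophenyl compound is again the weaker inhibitor of growth. Set side by side, the two steps run the same way and do not differ in size beyond what repeated measurements would give: the same change on two cores in this assay, a 12-fold higher number (1.08 log units; beyond the scatter) from compound 1 to compound 2 and a 9.5-fold higher number (0.98 log units; beyond the scatter) from compound 3 to compound 4, 1.3-fold (0.11 log units) apart, within the scatter of two such steps. Among the compounds shown here, this shows that the change carried over from the core of compound 1 to the core of compound 3, but it rests on only two cores, so it does not show that the step would hold on any further core, and it does not say what lies behind the step.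

The compounds shown leave open how other groups at that place, such as a nitrile, an amine or a methyl, would compare with fluoro and chloro. They also leave open whether the step would persist in a different assay or on other cells.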